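Amine substitution on the benzylamine series: dimethyl to diethyl

The compounds below may be only part of what the source reports. "The series", "measured", "known", "first", "only" and "open" are said of these compounds alone.

Measured compounds:
compound 1 `CNCc1ccc(Cl)c(-c2ccccc2OC)c1` gives 2400 nM in an assay on isolated protein for binding affinity to 5-hydroxytryptamine receptor 1E (Homo sapiens); on this read-out lower numbers stand for stronger inhibition and higher numbers for weaker inhibition
compound 2 `COc1ccccc1-c1cc(CN(C)C)ccc1Cl` gives 4100 nM in this assay

Within the data shown here, compound 2 has the highest of the two numbers so far, but its only neighbour, compound 1, sits within the scatter: a 1.7-fold higher number from compound 1 to compound 2 (0.23 log units; within the scatter). Among the measured compounds shown here, that single step, a methyl group on the amine nitrogen, is the only measured change that touches the amine, and it did not move the number beyond the scatter.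

Compound 3 `CCN(CC)Cc1ccc(Cl)c(-c2ccccc2OC)c1` carries the next extension of the same amine: diethylamino in place of dimethylamino on a saturated chain carbon bound to an aromatic carbon. The change lies on the same nitrogen as the step from compound 1 to compound 2, and adds two more carbons to it. For the measured compounds named here, with only one small step to go by, the expectation for compound 3 is a modest shift, if any, toward a higher number in this assay, a 1.3-fold higher number from compound 2 to compound 3 (0.13 log units; within the scatter), so compound 3 is estimated at 5500 nM with a range of 2200 nM to 14000 nM.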

Compound 3, inhibition constant: > 10000 nM
Compound 3 gave a limit, no number; the forecaster's own chance of this, stated with the estimate: 10%; middle value at least 1.8-fold (0.25 log units) away from the limit.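

In this assay compound 3 gives a limit and not a number: the limit of > 10000 nM in this assay, at which 1 of the 3 values shown sits. The amine nitrogen on the saturated chain carbon now shows a change beyond the scatter, with diethylamino in place of dimethylamino giving an at least 2.4-fold higher number from compound 2 to compound 3 (0.38 log units; beyond the scatter) and diethylamino in place of methylamino giving an at least 4.1-fold higher number from compound 1 to compound 3 (0.61 log units; beyond the scatter). The earlier step on this nitrogen, a 1.7-fold higher number from compound 1 to compound 2 (0.23 log units; within the scatter), showed no such separation, so among these three compounds only diethylamino stands apart from the other two amines.

On these data alone, both new steps are lower bounds, so the full size of the change remains open. Also open, as far as these compounds go, is how a primary amine, a pyrrolidine or a single N-ethyl-N-methylamino group would read in this assay, and so whether the change follows from chain length or from the number of carbons on the nitrogen.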